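Oxime in Place of Hydroxymethyl on a Fused Core

The source may hold more compounds than are shown below. What is called first, only, known or untested is meant among the compounds shown, and "the series" means these compounds.

Measured compounds:
compound 1, `Cc1ccc2c(Cc3nn4cc(-c5ccc(Cl)cc5)nc4s3)coc2c1`, 51.7%
compound 2, `Cc1ccc2c(Cc3nn4c(C=O)c(-c5ccc(Cl)cc5)nc4s3)coc2c1`, 42.5%
compound 3, `Cc1ccc2c(Cc3nn4c(CO)c(-c5ccc(Cl)cc5)nc4s3)coc2c1`, 45.9%

In a functional assay on the whole organism (strain Wistar albino) for inhibition, with Rattus norvegicus as the target, read by paw edema, with a stated time of 3 h, at a dose of 100 mg/kg by the oral route (on this read-out lower numbers stand for less inhibition and higher numbers for more inhibition at the one dose given (going by the name of the read-out)), the three measured compounds all fall within the usual scatter of one another. Compound 3 stands second highest of the three numbers: its nearest neighbour is compound 2, with a number 3.4 percentage points higher from compound 2 to compound 3 (within the scatter), and its furthest is compound 1, with a number 5.8 percentage points lower from compound 1 to compound 3 (within the scatter). Neither gap counts as a real difference.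

Compound 4, `Cc1ccc2c(Cc3nn4c(/C=N/O)c(-c5ccc(Cl)cc5)nc4s3)coc2c1`, differs from compound 3 by the change (a group of 3 heavy atoms (1 carbon, 1 nitrogen, 1 oxygen; no ring) in place of a group of 2 heavy atoms (1 carbon, 1 oxygen; no ring), on an aromatic carbon). Going by the values given here, the steps that bear on this place are the ones already seen there: formyl for hydrogen, a number 9.2 percentage points lower from compound 1 to compound 2 (within the scatter), hydroxymethyl for hydrogen, a number 5.8 percentage points lower from compound 1 to compound 3 (within the scatter), and hydroxymethyl for formyl, a number 3.4 percentage points higher from compound 2 to compound 3 (within the scatter). Every change at this carbon so far has stayed within the scatter, so no step beyond the scatter is expected for compound 4, in either direction. The expected step is a number 1.9 percentage points lower from compound 3 to compound 4 (within the scatter). In this assay compound 4 is therefore estimated at 44%, with a range from 32% to 56%.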

Compound 4, a percentage reported as inhibition, in the whole organism at one dose (the size of the read-out at that dose, not a potency): 10%
Estimate against measurement, compound 4: 34 percentage points above; measured number below the stated range.
By their numbers in this assay, from the lowest: compound 4; then compounds 2, 3 and 1 (each within the scatter of the next).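

Going by these compounds alone, on this carbon, next to the ring nitrogen, hydrogen, formyl and hydroxymethyl had stayed within the scatter of one another in this assay, and the oxime is the first group there to stand apart, with a number 35.9 percentage points lower from compound 3 to compound 4 (beyond the scatter), a number 32.5 percentage points lower from compound 2 to compound 4 (beyond the scatter) and a number 41.7 percentage points lower from compound 1 to compound 4 (beyond the scatter), each of them large. The position is therefore not indifferent to what it carries, even though the entering group, with 3 heavy atoms and 2 hydrogen-bond acceptors, differs only modestly in these counts from hydroxymethyl, with 2 heavy atoms and 1 hydrogen-bond acceptor. Nothing available accounts for this fall in activity.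

As far as these compounds go, it remains open whether the fall is particular to the oxime or extends to other groups on this carbon. An aminomethyl group, a carboxylic acid or the methyl ether of the oxime at this position would help to settle that.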